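A few compounds are considered here, and "the series" means these few. Any claim that something is new, unique, unknown or untested is made for them only; others in the source may bear on it.

compound 1 `C=C1C(=O)[C@@]23C(=O)OC[C@]4(C(=O)CCC(C)(C)[C@H]4C=O)[C@@H]2CC[C@@H]1[C@H]3O`: 3260 nM
compound 2 `C=C1C(=O)[C@@]23C(=O)OC[C@]4([C@@H](OC(C)=O)CCC(C)(C)[C@H]4C=O)[C@@H]2CC[C@@H]1[C@H]3O`: 8960 nM

In a functional assay on K562 cells (Homo sapiens) for antiproliferative activity, read by MTT assay, with a stated time of 72 h (on this read-out higher numbers stand for weaker inhibition and lower numbers for stronger inhibition), compound 1 gives 3260 nM, the lowest of the two numbers. Compound 2 gives 8960 nM. The gap between compound 1 and compound 2 lies beyond the usual scatter. Compound 3 `C=C1C(=O)[C@@]23C(=O)OC[C@]4(C(=O)CCC(C)(C)[C@H]4C=O)[C@@H]2CC[C@@H]1[C@H]3OC(=O)CCCCC1CCSS1` departs from compound 1 by a group of 11 heavy atoms (8 carbon, 1 oxygen, 2 sulfur; one five-membered non-aromatic ring with 2 hetero atoms) in place of a hydrogen atom, on an oxygen on a saturated carbon. Within the data shown here, no measured pair tests a change at this oxygen, so the expectation is tentative: a modest step toward stronger inhibition in this assay, possibly none beyond the scatter. The expected change is a 1.8-fold lower number from compound 1 to compound 3 (0.26 log units; within the scatter). For compound 3 the estimated value is 1800 nM, with an expected range of 500 nM to 6000 nM.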

Compound 3, half-maximal inhibitory concentration: 2590 nM
For compound 3 the middle estimate is 1.4-fold (0.16 log units) below the measured one, within the range that was stated.
By their numbers in this assay, from the lowest: compounds 3 and 1 (each within the scatter of the next); then compound 2.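

In this assay, a group of 11 heavy atoms with one five-membered non-aromatic ring with 2 hetero atoms, in place of the hydrogen atom on this oxygen, gives a 1.3-fold lower number from compound 1 to compound 3 (0.10 log units; within the scatter) and so shows that this oxygen can carry a group of this size with no change beyond the scatter. Nothing measured here accounts for this outcome. From the compounds shown here alone, whether the ring or the chain holding it matters remains open, and an acetyl group or a chain ending in an amine on this oxygen would separate the two.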